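The source may hold more compounds than are shown below. What is called first, only, known or untested is meant among the compounds shown, and "the series" means these compounds.

Measured compounds in an assay on T-REx-293 cells for inhibition of potassium channel subfamily T member 1 (Homo sapiens), read by patch clamp; a higher number here means a weaker inhibitor, a lower number a stronger inhibitor:

compound 1, `Cc1cncc(-c2noc([C@H](C)NC(=O)c3cc(C(F)(F)F)nn3C)n2)c1`: 1370 nM
compound 2, `C[C@H](NC(=O)c1cc(C(F)(F)F)nn1C)c1nc(-c2ccccn2)no1`: a limit of the assay, > 30000 nM
compound 3, `C[C@H](NC(=O)c1cc(C(F)(F)F)nn1C)c1nc(-c2ccnc(N(C)C)c2)no1`: 454 nM

All three share one core and differ only in the aromatic group attached to it. Compound 3 gives the lowest number and is the strongest inhibitor shown; its nearest neighbour is compound 1, with a 3.0-fold lower number from compound 1 to compound 3 (0.48 log units; beyond the scatter). For compound 2 only a limit is recorded, as described in the limit of > 30000 nM in this assay, at which 1 of the 3 values shown sits, so the step of an at least 66-fold lower number from compound 2 to compound 3 (1.82 log units; beyond the scatter) is at least that large.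

Compound 4, `C[C@H](NC(=O)c1cc(C(F)(F)F)nn1C)c1nc(-c2ccnc(C(F)F)c2)no1`, differs from compound 3 in one place: difluoromethyl in place of dimethylamino on an aromatic carbon. The two measured steps that bear on this change are the swaps of the aromatic group in a 3.0-fold lower number from compound 1 to compound 3 (0.48 log units; beyond the scatter) and an at least 66-fold lower number from compound 2 to compound 3 (1.82 log units; beyond the scatter), both large and both ending at compound 3, which shows that this assay responds strongly to what sits on that ring. Compound 4 keeps the ring of compound 3 but loses its dimethylamino group, so a weaker inhibitor is expected, with the step estimated as a 3.3-fold higher number from compound 3 to compound 4 (0.52 log units; beyond the scatter). For compound 4 the expected value is 1500 nM, estimated within 400 nM to 6000 nM.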

Compound 4, half-maximal inhibitory concentration: 61 nM
Compound 4: the middle estimate sits 25-fold (1.39 log units) above what was measured; measured number outside the range, below it.
By their numbers in this assay, from the lowest: compound 4; then compound 3; then compound 1. At a limit, above all of these: compound 2.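

In this assay the step of a 7.4-fold lower number from compound 3 to compound 4 (0.87 log units; beyond the scatter) shows that dimethylamino is not required on this carbon next to the ring nitrogen: difluoromethyl has the same count of heavy atoms, no nitrogen and no hydrogen-bond acceptor, yet gives the lower number. The step of a 22-fold lower number from compound 1 to compound 4 (1.35 log units; beyond the scatter) shows that, of the aromatic groups measured with a real number, the one carrying difluoromethyl gives the lowest. Compound 2 stands at a limit, so the step of an at least 490-fold lower number from compound 2 to compound 4 (2.69 log units; beyond the scatter) is a bound and not a measured size.

The compounds shown do not tell why difluoromethyl gives the lower number. On these data alone, whether trifluoromethyl, methoxy or a plain methyl group on this same carbon would give a still lower number also stays open.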